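Swapping an amine tail for a hydroxyethyl amine tail

The compounds below may be only part of what the source reports. "The series", "measured", "known", "first", "only" and "open" are said of these compounds alone.

Measured compounds:
compound 1 `CCOC(=O)c1c(C)oc2nc(Nc3ccccc3)nc(N3CCC(C)CC3)c12`, 26100 nM
compound 2 `CCCCNc1nc(Nc2ccccc2)nc2oc(C)c(C(=O)OCC)c12`, 50200 nM

These two compounds were tested in a functional assay on sSPC-A1 cells (Homo sapiens) for cytotoxicity, read by MTT assay, with a stated time of 48 h; a lower number here means a stronger inhibitor, a higher number a weaker inhibitor. Compound 1 gives 26100 nM. Compound 2 gives 50200 nM, the higher of the two numbers, though the step of a 1.9-fold higher number from compound 1 to compound 2 (0.28 log units; within the scatter) lies within the scatter, so the two cannot be told apart.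

Compound 3 `CCOC(=O)c1c(C)oc2nc(Nc3ccccc3)nc(NCCO)c12` has not yet been measured. It differs from compound 2 by hydroxy in place of ethyl on a saturated chain carbon, two bonds along the chain from a nitrogen on an aromatic ring. Among the measured compounds shown here, the only measured step, a 1.9-fold higher number from compound 1 to compound 2 (0.28 log units; within the scatter), also changed the group on that ring nitrogen and did not move the number beyond the scatter. For the measured compounds named here, no measured step introduces a hydroxy group, so nothing here points to a change in either direction.

Compound 3 is therefore expected to show roughly the same number as compound 2, with an estimated step of a 1.0-fold lower number from compound 2 to compound 3 (0.00 log units; within the scatter). The estimate for compound 3 is 50000 nM, with a range from 20000 nM to 125000 nM.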

Compound 3, half-maximal inhibitory concentration: 24200 nM
The estimate for compound 3 lay 2.1-fold (0.32 log units) above the measured number; measured number inside the range.
By their numbers in this assay, from the lowest: compounds 3, 1 and 2 (each within the scatter of the next, the first and the last beyond it).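

In this assay, among the compounds shown here, hydroxy in place of ethyl on this saturated chain carbon gives a modest change (a 2.1-fold lower number from compound 2 to compound 3 (0.32 log units; beyond the scatter)), the first step in this short series to pass beyond the scatter, so the far end of this tail can shift the number. The (2-hydroxyethyl)amino tail and the 4-methylpiperidin-1-yl group, in contrast, cannot be told apart (a 1.1-fold lower number from compound 1 to compound 3 (0.03 log units; within the scatter)), so this small hydroxy-bearing chain and the ring amine read alike at this position. Nothing measured here explains the shift.

The compounds shown do not separate the effect of adding hydroxy from that of shortening the chain, as butyl gives way to 2-hydroxyethyl in a single change. On these data alone, what a methoxy group or an amine at the end of the same chain would give remains open, as does a longer chain ending in hydroxy.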